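Nitro to amino on a trimethoxyphenyl chalcone

This account rests on a few compounds, and the source may have more. Where it says the series, first, only, none or still open, it means among the compounds named here.

Measured compounds:
compound 1 `COc1ccc(C(=O)/C=C/c2cc(OC)c(OC)c(OC)c2)cc1N` — 67000 nM
compound 2 `COc1ccc(/C=C/C(=O)c2cc(OC)c(OC)c(OC)c2)cc1[N+](=O)[O-]` — > 100000 nM

In a functional assay on B16 cells (Mus musculus) for cytotoxicity, read by MTT assay, with a stated time of 3 days (a higher number here means a weaker inhibitor, a lower number a stronger inhibitor), compound 1 gives 67000 nM. For compound 2 the result is only a limit, > 100000 nM, which matches (the limit of > 100000 nM in this assay, at which 1 of the 2 values shown sits). Compound 3 `COc1ccc(/C=C/C(=O)c2cc(OC)c(OC)c(OC)c2)cc1N` differs from compound 2 by amino in place of nitro on an aromatic carbon. For the measured compounds named here, with no measured step of this kind, the change is expected to be an at least 2.0-fold lower number from compound 2 to compound 3 (0.30 log units; that floor lies within the scatter), a modest gain beyond the scatter. Compound 3 is estimated at 50000 nM, within 15000 nM to 150000 nM.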

Compound 3, half-maximal inhibitory concentration: 240 nM
For compound 3 the middle estimate is 210-fold (2.32 log units) above the measured one; the measured number lies below the stated range.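

In this assay, amino in place of nitro on this aromatic carbon, ortho to a methoxy group, gives an at least 410-fold lower number from compound 2 to compound 3 (2.61 log units; beyond the scatter). For the compounds shown here, this shows that the position responds strongly to this exchange, which the earlier compounds alone could not show. Compound 2 gives only a limit, so the step is a floor: the limit of > 100000 nM in this assay, at which 1 of the 3 values shown sits.

The compounds shown leave open whether a hydroxyl, an acetamide or a dimethylamino group at this position would match amino. They also leave open whether nitro in place of amino on the core of compound 1 would give a step of similar size.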